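Series notes: chain substituent on the aromatic nitrogen

A few compounds are considered here, and "the series" means these few. Any claim that something is new, unique, unknown or untested is made for them only; others in the source may bear on it.

Among the compounds with values here, compound 2 `c1ccc(Cn2cc(-c3ccc4ccccc4c3)nn2)cc1` gives 3890 nM in a functional assay on B16 cells (Mus musculus) for cytotoxicity, read by MTT assay, with a stated time of 48 h (a higher number here means a weaker inhibitor, a lower number a stronger inhibitor), the lowest of the two numbers so far. Within the data shown here, compound 1 `CC1(C)OC[C@H](Cn2cc(-c3ccc4ccccc4c3)nn2)O1` gives 12000 nM in this assay; the step of a 3.1-fold lower number from compound 1 to compound 2 (0.49 log units; beyond the scatter) is the only measured change at this position and it lowered the number. Compound 3 `OCCCn1cc(-c2ccc3ccccc3c2)nn1` is not yet measured; it differs from compound 2 by 2-hydroxyethyl in place of phenyl on a saturated chain carbon bound to an aromatic nitrogen. This change removes the phenyl that the step of a 3.1-fold lower number from compound 1 to compound 2 (0.49 log units; beyond the scatter) had brought in and puts in its place a short chain carrying one hydrogen-bond donor and one acceptor, which is closer in character to the group of compound 1 than to that of compound 2. Among the measured compounds shown here, the one bearing step therefore points to a higher number, and the step of a 2.3-fold higher number from compound 2 to compound 3 (0.36 log units; beyond the scatter) is expected, with wide uncertainty. Compound 3 is estimated at 9000 nM, within 3500 nM to 25000 nM.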

Compound 3, half-maximal inhibitory concentration: > 100000 nM
Compound 3 ended at the assay's limit; the forecaster's own chance of this, stated with the estimate: 10%; middle value at least 11-fold (1.04 log units) from the limit.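

In this assay compound 3 gives > 100000 nM, which is a limit of the assay and not a number. The earlier step suggested modest movement at this position, but the new steps are far larger and give only lower bounds, an at least 25-fold higher number from compound 2 to compound 3 (1.41 log units; beyond the scatter) and an at least 8.3-fold higher number from compound 1 to compound 3 (0.92 log units; beyond the scatter), placing 3-hydroxypropyl on the high-number side of both benzyl and the group of compound 1. The true size of both steps stays open upward, and how far compound 3 lies past the limit cannot be read: the limit of > 100000 nM in this assay, at which 1 of the 3 values shown sits.

The compounds shown do not separate the loss of the phenyl from the entry of the hydroxyl in this change. A plain butyl chain or a 3-aminopropyl group on the same aromatic nitrogen would bear on that question.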